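Replacing 2-methoxyphenyl with 4-nitrophenyl in compound 3

This account rests on a few compounds, and the source may have more. Where it says the series, first, only, none or still open, it means among the compounds named here.

Values in a functional assay on Ehrlich cells (Mus musculus) for antiproliferative activity, read by trypan blue exclusion, with a stated time of 2 h; on this read-out higher numbers stand for weaker inhibition and lower numbers for stronger inhibition:
- compound 1 `Cc1ccc(C2C(C#N)=C(N)N(c3ccc(S(N)(=O)=O)cc3)C3=C2C(=O)CCC3)cc1`: 50 ug/mL
- compound 2 `N#CC1=C(N)N(c2ccc(S(N)(=O)=O)cc2)C2=C(C(=O)CCC2)C1c1ccc(O)cc1`: 3 ug/mL
- compound 3 `COc1ccccc1C1C(C#N)=C(N)N(c2ccc(S(N)(=O)=O)cc2)C2=C1C(=O)CCC2`: > 100 ug/mL (a limit)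

Compound 3 stands at the limit of > 100 ug/mL in this assay, at which 1 of the 3 values shown sits, so it has no numerical reading. Compound 4 `N#CC1=C(N)N(c2ccc(S(N)(=O)=O)cc2)C2=C(C(=O)CCC2)C1c1ccc([N+](=O)[O-])cc1` carries 4-nitrophenyl in place of 2-methoxyphenyl on a saturated ring carbon.

Changes to this group have already shifted the read-out. The measured steps are an at least 33-fold higher number from compound 2 to compound 3 (1.52 log units; beyond the scatter), which is large, and an at least 2.0-fold higher number from compound 1 to compound 3 (0.30 log units; that floor lies within the scatter), whose floor lies within the scatter. The step of a 17-fold lower number from compound 1 to compound 2 (1.22 log units; beyond the scatter) is also large, so the group's identity matters and a 4-substituent alone does not fix the value. Among the compounds with a 4-substituted phenyl group, compound 1 gives 50 ug/mL and compound 2 gives 3 ug/mL, and compound 4 is expected to read as a number in that region. The expected change is an at least 5.0-fold lower number from compound 3 to compound 4 (0.69 log units; beyond the scatter), towards a lower number. Compound 4 is estimated at 20 ug/mL, with an expected range of 3 ug/mL to 80 ug/mL.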

Compound 4, half-maximal inhibitory concentration: 2.5 ug/mL
Compound 4: middle estimate off by 8.0-fold (0.90 log units), on the high side, outside the stated range (below it).
By their numbers in this assay, from the lowest: compounds 4 and 2 (each within the scatter of the next); then compound 1. At a limit, above all of these: compound 3.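

In this assay, the 4-nitrophenyl and 4-hydroxyphenyl groups on the saturated ring carbon cannot be told apart, with a 1.2-fold lower number from compound 2 to compound 4 (0.08 log units; within the scatter), so two quite different 4-substituents now share one level, whereas the methyl group of compound 1 goes against any such grouping, with a 20-fold lower number from compound 1 to compound 4 (1.30 log units; beyond the scatter). Exchanging 2-methoxyphenyl for 4-nitrophenyl gives an at least 40-fold lower number from compound 3 to compound 4 (1.60 log units; beyond the scatter), which shows that this position can span a wide range with a nitro-bearing ring at the active end. Compound 3 remains a limit rather than a number: the limit of > 100 ug/mL in this assay, at which 1 of the 4 values shown sits.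

Still open, from the compounds shown here alone, is whether the methoxy group itself or its place on the ring sets compound 3 apart, a question that a 4-methoxyphenyl group would address. Also open, going by these compounds, is how a 4-aminophenyl group or a 4-carboxyphenyl group would read at this position.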